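Benzofuran-piperidine series: acetamido added on the piperidine ring

The source may report more compounds than this note shows. Statements on the series, on what has been measured and on what is new or still open speak of the compounds shown alone.

Measured so far:
Compound 2, `c1cnc2nc(Oc3ccc4c(CN5CCCCC5)coc4c3)sc2c1`: 4.6 nM
Compound 1, `c1ccc2sc(Oc3ccc4c(CN5CCCCC5)coc4c3)nc2c1`: 67 nM

Of the compounds shown here, two have been measured in an in vitro assay on Sf9 cells for inhibition of leukotriene A-4 hydrolase (Homo sapiens), read by immunoassay, with stated times of 10 min and 30 min; a higher number here means a weaker inhibitor, a lower number a stronger inhibitor. Compound 2 gives 4.6 nM, the lowest of the two numbers; compound 1 gives 67 nM, a higher number, and the gap lies beyond the scatter. Among the compounds with values here, the two differ in their core and no single-point step joins them, so the gap says only what the two values show.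

Compound 3 `CC(=O)NC1CCN(Cc2coc3cc(Oc4nc5ncccc5s4)ccc23)CC1` is not yet measured. It differs from compound 2 by acetamido in place of hydrogen on a saturated ring carbon. Within the data shown here, no measured pair in this set makes a comparable change, so the size of the step cannot be read from the data. The expected step of a 1.2-fold lower number from compound 2 to compound 3 (0.06 log units; within the scatter) is none beyond the scatter. The estimate for compound 3 in this assay is 4 nM, with a range from 1.5 nM to 12 nM.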

Compound 3, half-maximal inhibitory concentration: 3.7 nM
Compound 3: middle estimate off by 1.1-fold (0.03 log units), on the high side; low and high end bracket the measured number.
By their numbers in this assay, from the lowest: compounds 3 and 2 (each within the scatter of the next); then compound 1.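

In this assay, the change from piperidin-1-yl to 4-acetamidopiperidin-1-yl gives a 1.2-fold lower number from compound 2 to compound 3 (0.09 log units; within the scatter) and leaves the two compounds indistinguishable. Within the data shown here, this is the first reading with anything other than hydrogen on this saturated ring carbon, three ring bonds from the ring nitrogen, and it shows that an acetamido group can stand there without a measurable loss in this assay. No measurement available here offers an explanation for this outcome.

As far as these compounds go, whether the same holds for other groups at this carbon, such as a primary amine, a carboxylic acid or a longer acyl chain, remains open. Also open, from the compounds shown here alone, is whether acetamido behaves alike on the core of compound 1 , which gives 67 nM without it, as the change is read on one core only.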